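This account rests on a few compounds, and the source may have more. Where it says the series, first, only, none or still open, it means among the compounds named here.

Measured so far in a functional assay on IMR-32 cells (Homo sapiens) for cytotoxicity, read by sulforhodamine B assay, with a stated time of 48 h; a lower number here means a stronger inhibitor, a higher number a weaker inhibitor:
compound 1, `CC(=O)N1N=C(c2cccc3ccccc23)CC1c1ccco1`, gives 8000 nM
compound 2, `COc1ccc(C2CC(c3cccc4ccccc34)=NN2C(C)=O)cc1`, gives 4990 nM
compound 3, `O=CCN1N=C(c2ccc3ccccc3c2)CC1c1ccco1`, gives 11000 nM

Compound 1 and compound 2 differ in one place, (4-methoxyphenyl in place of furan-2-yl on a saturated ring carbon), and this gave a 1.6-fold lower number from compound 1 to compound 2 (0.20 log units; within the scatter). Compound 3 is built from the same atoms as compound 1 joined differently; the difference between the two cores is not broken down here. Compound 4, `COc1ccc(C2CC(c3ccc4ccccc4c3)=NN2CC=O)cc1`, has not been measured. It differs from compound 3 by 4-methoxyphenyl in place of furan-2-yl on a saturated ring carbon. The surroundings are not identical: in compound 1 the ring atom beside the changed carbon bears an acetyl group, in compound 3 it bears a formylmethyl group, so this is the same kind of change rather than the same one. A similar small step is expected, a 1.6-fold lower number from compound 3 to compound 4 (0.20 log units; within the scatter), because a 1.6-fold lower number from compound 1 to compound 2 (0.20 log units; within the scatter) was seen on the related core. Compound 4 is therefore estimated at 7000 nM, most likely between 3500 nM and 14000 nM.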

Compound 4, half-maximal inhibitory concentration: 4120 nM
Beside the measured number, compound 4's estimate is 1.7-fold (0.23 log units) above it, and the stated range covers the measured number.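

On the core of compound 3, putting 4-methoxyphenyl in place of furan-2-yl on the saturated ring carbon gives a 2.7-fold lower number from compound 3 to compound 4 (0.43 log units; beyond the scatter) in this assay. The step on this core cannot be told apart in size from the step on the earlier core, so the change carries over between these two cores: the same change on two cores in this assay, a 1.6-fold lower number (0.20 log units; within the scatter) from compound 1 to compound 2 and a 2.7-fold lower number (0.43 log units; beyond the scatter) from compound 3 to compound 4, 1.7-fold (0.22 log units) apart, within the scatter of two such steps This does not show why the number moves, and two pairs of compounds give no rule for other cores, especially as only the newer step lies beyond the scatter.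

Still open, from the compounds shown here alone, is how a simple phenyl or a pyridine ring would behave on that carbon. Also open, going by these compounds, is whether a carboxylic acid or a longer chain on the ring nitrogen would alter the step.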